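This account rests on a few compounds, and the source may have more. Where it says the series, first, only, none or still open, it means among the compounds named here.

Compound 1 `O=C1c2c[n+]([O-])c3ccccc3c2C(=O)c2c1c1ccccc1n2Cc1cn([C@H]2O[C@H](CO)[C@@H](O)[C@H]2O)nn1` gives, in a functional assay on SH-SY5Y cells (Homo sapiens) for cytotoxicity, read by MTT assay, with a stated time of 72 h (on this read-out lower numbers stand for stronger inhibition and higher numbers for weaker inhibition), a value of 1340 nM.
Compound 2 `CN1CCN(CCCCn2c3c(c4ccccc42)C(=O)c2c[n+]([O-])c4ccccc4c2C3=O)CC1` gives in this assay a value of 100 nM.

Of the two measured compounds, compound 2 has the lower number in this assay, and the gap between the value of compound 2 and that of compound 1 is beyond the usual scatter of this kind of measurement; the two compounds differ in more than one place, so nothing more is read from that gap.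

Compound 3 `CN1CCN(CCCCCn2c3c(c4ccccc42)C(=O)c2c[n+]([O-])c4ccccc4c2C3=O)CC1` keeps the core of compound 2 and differs from it only in the chain that carries the 4-methylpiperazin-1-yl group: (4-methylpiperazin-1-yl)methyl in place of 4-methylpiperazin-1-yl on a saturated chain carbon, four bonds along the chain from an aromatic nitrogen

The chain grows by one carbon while the group at its end stays the same. Nothing in the measured compounds shows how such a lengthening acts here, so the step is expected to stay within the scatter: compound 3 is expected to come out near compound 2 at 120 nM, between 50 nM and 300 nM, a step of a 1.2-fold higher number from compound 2 to compound 3 (0.08 log units; within the scatter).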

Compound 3, half-maximal inhibitory concentration: 830 nM
Compound 3: middle estimate off by 6.9-fold (0.84 log units), on the low side; the measured number lies above the stated range.
By their numbers in this assay, from the lowest: compound 2; then compounds 3 and 1 (each within the scatter of the next).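

In this assay the chain carrying the 4-methylpiperazin-1-yl group proves to matter, as (4-methylpiperazin-1-yl)methyl in place of 4-methylpiperazin-1-yl on this saturated chain carbon gives an 8.3-fold higher number from compound 2 to compound 3 (0.92 log units; beyond the scatter) and so a change beyond the usual scatter. Going by these compounds alone, the earlier pair differed in more than one place, so this is the first reading of a single change: with the core and the end group kept, lengthening the chain alone moves the number towards weaker inhibition. Nothing available explains why this lengthening has such an effect.

A single step gives a direction between two chain lengths, not a trend across chain lengths. On these data alone, it remains open whether a shorter chain or a still longer chain would continue this direction, and whether a dimethylamino group at the chain end would respond to lengthening in the same way.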